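Swapping chloro for trifluoromethyl on the terminal ring

A few compounds are considered here, and "the series" means these few. Any claim that something is new, unique, unknown or untested is made for them only; others in the source may bear on it.

Compound 1 `COc1cc(-c2nn(-c3cccc(NC(=O)Nc4ccc(Cl)c(Cl)c4)c3)cc2-c2ccncc2)ccc1Cl` gives 2770 nM in a functional assay on KM12 cells (Homo sapiens) for inhibition, read by sulforhodamine B assay, with a stated time of 48 h; on this read-out higher numbers stand for weaker inhibition of growth and lower numbers for stronger inhibition of growth.
Compound 2 `O=C(Nc1cccc(-n2cc(-c3ccncc3)c(-c3ccc(Cl)c(O)c3)n2)c1)Nc1ccc(Cl)c(Cl)c1` gives 4470 nM in this assay.
Compound 3 `COc1cc(-c2nn(-c3cccc(NC(=O)Nc4cccc(C(F)(F)F)c4)c3)cc2-c2ccncc2)ccc1Cl` gives 1980 nM in this assay.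

Compound 2 carries the highest of the three numbers. Its nearest neighbour is compound 1, with a 1.6-fold higher number from compound 1 to compound 2 (0.21 log units; within the scatter), which is within the scatter. Compound 3 sits furthest away, and that gap lies beyond the scatter.

Compound 4 `O=C(Nc1cccc(-n2cc(-c3ccncc3)c(-c3ccc(Cl)c(O)c3)n2)c1)Nc1ccc(Cl)c(C(F)(F)F)c1` arises from compound 2 by one change: trifluoromethyl in place of chloro on an aromatic carbon.

Going by the values given here, only one measured step speaks to a change of this sort. Between compound 1 and compound 3 the same terminal ring is altered, from 3,4-dichlorophenyl to 3-(trifluoromethyl)phenyl, and the result was a 1.4-fold lower number from compound 1 to compound 3 (0.15 log units; within the scatter), a shift that stays within the scatter. Among the compounds with values here, that change removes a chloro group and brings in a trifluoromethyl at once, whereas the step to compound 4 exchanges only the one group, so the comparison is loose. On this basis the step to compound 4 is expected to be small in this assay, with a slight lean toward a lower number, as a 1.3-fold lower number from compound 2 to compound 4 (0.11 log units; within the scatter).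

Compound 4 is therefore estimated at 3500 nM, with a range from 1500 nM to 8000 nM.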

Compound 4, concentration for total growth inhibition: 3510 nM
Estimate against measurement, compound 4: 1.0-fold (0.00 log units) below, and the stated range covers the measured number.
By their numbers in this assay, from the lowest: compounds 3, 1, 4 and 2 (each within the scatter of the next, the first and the last beyond it).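

With the neighbouring chloro group held in place, putting trifluoromethyl in place of chloro gives a 1.3-fold lower number from compound 2 to compound 4 (0.11 log units; within the scatter) in this assay, and this is the first step shown that reads this exchange alone at this position, on an aromatic carbon ortho to a chloro group and meta to a large group; the earlier step, a 1.4-fold lower number from compound 1 to compound 3 (0.15 log units; within the scatter), also took away a chloro group in the same move. Here a group of 4 heavy atoms enters where a group of 1 heavy atom leaves, yet compound 2 and compound 4 cannot be told apart on this read-out, so this position accepts the larger of these two groups without a step that rises above the scatter. No measured property is at hand to account for this result.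

The compounds shown leave open whether the same exchange would read alike on compound 1, which keeps the methyl on the oxygen that is free in compound 2. They also leave open whether a group of another kind at this position, such as an amine or a carboxylic acid, would give a step beyond the scatter.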